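This account rests on a few compounds, and the source may have more. Where it says the series, first, only, none or still open, it means among the compounds named here.

Working notes on the series in an assay on cells for inhibition of MAP kinase-interacting serine/threonine-protein kinase 1 (Homo sapiens), read by mobility shift assay, with stated times of 10 min and 60 min, in the presence of a further agent that is not named here; a lower number here means a stronger inhibitor, a higher number a weaker inhibitor. Compound 1 `Cc1cc(-c2cccnc2)ccc1C(N)=O` gives 22000 nM in this assay. Compound 2 `NC(=O)c1ccc(-c2ccc(N)nc2)cc1` gives 34000 nM, a number within the scatter of the value of compound 1. Compound 3 `Cn1cc(-c2cncc(-c3ccc(C(N)=O)cc3)c2)cn1` gives 800 nM, a number far below that of compound 1 and beyond the scatter. Compound 1 thus sits with compound 2 at the weaker end of the three numbers, with compound 3 well apart. Compound 4 `CC(C)Oc1cc(-c2cccnc2)ccc1C(N)=O` is not yet measured; it differs from compound 1 in one place: isopropoxy in place of methyl on an aromatic carbon. Among the measured compounds shown here, no measured pair shows this change, so no step is available to lean on. The expected step is a 1.8-fold lower number from compound 1 to compound 4 (0.26 log units; within the scatter), leaning toward a lower number but not clearly beyond the scatter. Compound 4 is estimated at 12000 nM in this assay, with a range from 3000 nM to 45000 nM.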

Compound 4, half-maximal inhibitory concentration: 880 nM
The estimate for compound 4 lay 14-fold (1.13 log units) above the measured number; the measured number lies below the stated range.
By their numbers in this assay, from the lowest: compounds 3 and 4 (each within the scatter of the next); then compounds 1 and 2 (each within the scatter of the next).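

In this assay the change to isopropoxy in place of methyl, ortho to the carbamoyl group, gives a 25-fold lower number from compound 1 to compound 4 (1.40 log units; beyond the scatter) on an otherwise unchanged core. Among the compounds shown here, this is the first step read at this position, and it shows that the number responds strongly to the group placed there. Nothing measured here accounts for the size of this step. The compounds shown leave open whether the gain follows the ether oxygen or the branched carbon chain. Methoxy, isopropyl and an amine at the same position would separate these readings.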